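This account rests on a few compounds, and the source may have more. Where it says the series, first, only, none or still open, it means among the compounds named here.

Compound 2 `Oc1cccc(-c2cc(-c3ccccc3)nc(-c3ccc(Cl)cc3)c2)c1` and compound 3 `Oc1ccc(-c2cc(-c3ccccc3)nc(-c3ccc(Cl)cc3)c2)cc1` share a core and differ by 4-hydroxyphenyl in place of 3-hydroxyphenyl on an aromatic carbon. In a functional assay on T47D cells (Homo sapiens) for cytotoxicity, read by CCK-8 assay and cell counting, with a stated time of 2 days (on this read-out lower numbers stand for stronger inhibition and higher numbers for weaker inhibition), compound 2 gives 11300 nM, and compound 3 gives 4270 nM, the step being a 2.6-fold lower number from compound 2 to compound 3 (0.42 log units; beyond the scatter). Compound 1 `Oc1cccc(-c2cc(-c3ccc(Cl)cc3)nc(-c3ccccn3)c2)c1` carries pyridin-2-yl in place of phenyl on an aromatic carbon; in this assay compound 1 gives 13900 nM, which makes the step of a 1.2-fold higher number from compound 2 to compound 1 (0.09 log units; within the scatter). Compound 4 `Oc1ccc(-c2cc(-c3ccc(Cl)cc3)nc(-c3ccccn3)c2)cc1` has not yet been measured. It differs from compound 3 by pyridin-2-yl in place of phenyl on an aromatic carbon, the same kind of change as that from compound 2 to compound 1, though here the place is meta to a 4-hydroxyphenyl group rather than a 3-hydroxyphenyl group. Because a 1.2-fold higher number from compound 2 to compound 1 (0.09 log units; within the scatter) stayed within the scatter, a similarly small step is expected for compound 4 in this assay, namely a 1.2-fold higher number from compound 3 to compound 4 (0.07 log units; within the scatter). Compound 4 is therefore estimated at 5000 nM, most likely between 2500 nM and 10000 nM.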

Compound 4, half-maximal inhibitory concentration: 25900 nM
Beside the measured number, compound 4's estimate is 5.2-fold (0.71 log units) below it; the measured number lies above the stated range.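

In this assay, pyridin-2-yl in place of phenyl gave a 6.1-fold higher number from compound 3 to compound 4 (0.78 log units; beyond the scatter), so this change did not carry over unchanged from one core to the other: the same change on two cores in this assay, a 1.2-fold higher number (0.09 log units; within the scatter) from compound 2 to compound 1 and a 6.1-fold higher number (0.78 log units; beyond the scatter) from compound 3 to compound 4, 4.9-fold (0.69 log units) apart, beyond the scatter of two such steps The move from 3-hydroxyphenyl to 4-hydroxyphenyl likewise gave a different result on the core of compound 1, with a 1.9-fold higher number from compound 1 to compound 4 (0.27 log units; within the scatter): the same change on two cores in this assay, a 2.6-fold lower number (0.42 log units; beyond the scatter) from compound 2 to compound 3 and a 1.9-fold higher number (0.27 log units; within the scatter) from compound 1 to compound 4, 4.9-fold (0.69 log units) apart, beyond the scatter of two such steps These four compounds show that the two changes did not act independently here, but they do not show why, or whether this holds beyond this series.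

As far as these compounds go, it remains open whether the same dependence on the core would appear with an amine or a methoxy group in place of the hydroxy group. From the compounds shown here alone, whether it would extend to other cell lines is also open.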